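Chloro for hydrogen on a fused bicyclic core

The compounds below may be only part of what the source reports. "The series", "measured", "known", "first", "only" and "open" are said of these compounds alone.

The measured compounds and their values in a functional assay on CCRF-CEM cells (Homo sapiens) for inhibition, read by sulforhodamine B assay, with a stated time of 48 h, tested at 10 uM; a lower number here means less inhibition of growth, a higher number more inhibition of growth at the concentration tested:
Compound 1, `C/C(=N/O)c1ccc(NC(=O)Cn2nc(-c3ccccc3)nc2N)cc1`, 6.77%
Compound 2, `c1ccc(-c2nc3sc(-c4ccccc4)cn3n2)cc1`, 13%
Compound 3, `CC(=O)c1ccc(NC(=O)Cn2nc(-c3ccc(Cl)cc3)nc2N)cc1`, 19.9%

Compound 2 stands second highest of the three numbers in this assay. Its nearest neighbour is compound 1, whose value lies a little lower but within the scatter; the furthest is compound 3, whose value lies somewhat higher, also within the scatter. All three values therefore sit close together, and none of the compounds can be called more or less active than another.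

The unmeasured compound 4, `Clc1ccc(-c2cn3nc(-c4ccccc4)nc3s2)cc1`, differs from compound 2 in one place: chloro in place of hydrogen on an aromatic carbon. Going by the values given here, no step between measured compounds mirrors this change. Compound 1 and compound 3, which differ in more than one place, show that a 4-chlorophenyl in place of phenyl together with a second change left the values within the scatter of one another. For compound 4 a step of a number 2 percentage points higher from compound 2 to compound 4 (within the scatter) is expected, that is, none beyond the scatter in either direction. Compound 4 is thus estimated at 15%, with a range from 2% to 35%.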

Compound 4, percent growth inhibition at one concentration: 6%
Compound 4: middle estimate off by 9 percentage points, on the high side; the range from low to high includes it.
By their numbers in this assay, from the lowest: compounds 4, 1, 2 and 3 (each within the scatter of the next, the first and the last beyond it).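

Going by these compounds alone, the chloro group, on an aromatic carbon of a six-membered aromatic ring of carbon only and para to a large group, gives the first reading of phenyl to 4-chlorophenyl as a single change, since compound 1 and compound 3 differ in more than one place. In this assay the reading is a number 7 percentage points lower from compound 2 to compound 4 (within the scatter), so at this position the change leaves compound 2 and compound 4 indistinguishable at the concentration tested. No measurement of any other kind is at hand to bear on this result.

What the compounds shown leave open is whether a methoxy group, an amine or a carboxylic acid at this same place would give a step beyond the scatter. Also open, from the compounds shown here alone, is whether chloro on the second phenyl of the shared core would read any differently from chloro here.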